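Swapping the benzyl halogen: from compound 3 to compound 4

This account rests on a few compounds, and the source may have more. Where it says the series, first, only, none or still open, it means among the compounds named here.

Of the compounds shown here, three built on a shared core have been measured in an assay on isolated protein for inhibition of aldehyde dehydrogenase 1A1 (Homo sapiens), read by spectrophotometry, tested at 10 uM; on this read-out higher numbers stand for more inhibition at the one concentration tested (going by the name of the read-out) and lower numbers for less inhibition. Compound 1 `Cc1cccc(Cn2c(CN3CCN(C(=O)c4ccc(C(C)C)cc4)CC3)nc3ccccc32)c1` gives 67.6%, compound 2 `Cc1cccc(Cn2c(CN3CCN(C(=O)c4ccc(Cl)cc4)CC3)nc3ccccc32)c1` gives 23.2%, and compound 3 `O=C(C1CC1)N1CCN(Cc2nc3ccccc3n2Cc2ccccc2F)CC1` gives 40.7%. On these numbers compound 3 stands second highest of the three, beyond the scatter from both compound 2 below it and compound 1 above it.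

Compound 4 `O=C(C1CC1)N1CCN(Cc2nc3ccccc3n2Cc2cccc(Cl)c2)CC1` is not yet measured. It differs from compound 3 only in that (3-chlorophenyl in place of 2-fluorophenyl on a saturated chain carbon bound to an aromatic nitrogen). Among the measured compounds shown here, the single measured step, a number 44.4 percentage points lower from compound 1 to compound 2 (beyond the scatter), concerns a different part of the shared core, chloro in place of isopropyl on an aromatic carbon, so it does not bear directly on this change; it shows only that one group swap can move this read-out by a large amount. For the measured compounds named here, with no step at the saturated chain carbon bound to an aromatic nitrogen to lean on, no direction can be expected beyond the scatter, and compound 4 is estimated at 40%, within 15% to 65%. That estimate means a step of a number 0.7 percentage points lower from compound 3 to compound 4 (within the scatter) is expected, with wide uncertainty.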

Compound 4, a percentage reported as inhibition, at one concentration (the size of the read-out at that concentration, not a potency): 71.6%
Beside the measured number, compound 4's estimate is 31.6 percentage points below it, outside the stated range (above it).
By their numbers in this assay, from the lowest: compound 2; then compound 3; then compounds 1 and 4 (each within the scatter of the next).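

Among the compounds shown here, this is the first step read at the saturated chain carbon bound to an aromatic nitrogen, and in this assay it is large (a number 30.9 percentage points higher from compound 3 to compound 4 (beyond the scatter)), with 3-chlorophenyl in place of 2-fluorophenyl. The earlier step concerned an aromatic carbon elsewhere on the shared core, so this result shows that this second place can also move the read-out strongly. The swap does this while the count of 7 heavy atoms stays the same in the group that leaves and the group that enters, and no measurement here accounts for the rise.

The step changes both the halogen and its place on the ring at once, and the compounds shown cannot tell which of the two carries it. Also open, from the compounds shown here alone, is how this position responds to a different kind of group on the ring, such as a methoxy group or an amine.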